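The source may hold more compounds than are shown below. What is called first, only, known or untested is meant among the compounds shown, and "the series" means these compounds.

Measured compounds in an in vitro functional assay on 1321-N1 cells for agonist activity at Free fatty acid receptor 1 (Homo sapiens), read by fluorescence, spectrophotometry and calcium flux; on this read-out higher numbers stand for larger maximal responses and lower numbers for smaller maximal responses:
- compound 1, `COc1nccc(C#Cc2ccc(CCC(=O)O)cc2)n1`: 109%
- compound 2, `O=C(O)CCc1ccc(C#Cc2ccnc(Cl)c2)cc1`: 94%
- compound 3, `Cc1ccccc1-c1cc(C#Cc2ccc(CCC(=O)O)cc2)ccn1`: 92%

Compound 3 gives the lowest of these three numbers. Its nearest neighbour is compound 2, whose value lies only slightly higher and within the scatter of repeated measurements, so the two cannot be told apart. Compound 1 stands furthest away, with a number beyond the scatter above compound 3.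

Compound 4, `O=C(O)CCc1ccc(C#Cc2ccncc2)cc1`, has not been measured yet. It differs from compound 3 in one place: hydrogen in place of 2-methylphenyl on an aromatic carbon. The site is an aromatic carbon of a six-membered ring with one nitrogen, next to the ring nitrogen and meta to a large group.

Going by the values given here, one measured step bears on this change. Replacing chloro with 2-methylphenyl at that same position gave a number 2 percentage points lower from compound 2 to compound 3 (within the scatter), a change inside the scatter. That step suggests this position tolerates very different groups without a clear shift in maximal response. Removing the 2-methylphenyl for hydrogen is therefore expected to give a step of about a number 3 percentage points higher from compound 3 to compound 4 (within the scatter), in no clear direction beyond the scatter. Compound 4 is estimated at 95%, with a range from 78% to 112%.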

Compound 4, largest response reached (reported as efficacy), in percent of the reference or control that the assay uses: 100%
The estimate for compound 4 lay 5 percentage points below the measured number, within the range that was stated.
By their numbers in this assay, from the lowest: compounds 3, 2, 4 and 1 (each within the scatter of the next, the first and the last beyond it).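

Going by these compounds alone, the earlier pair showed only that one group could replace another on this aromatic carbon next to the ring nitrogen. Compound 4 shows that in this assay the maximal response does not depend on having any such group there, with a number 8 percentage points higher from compound 3 to compound 4 (within the scatter) for hydrogen in place of 2-methylphenyl and a number 6 percentage points higher from compound 2 to compound 4 (within the scatter) for hydrogen in place of chloro. Hydrogen, chloro and 2-methylphenyl, with its 7 heavy atoms, therefore give maximal responses that cannot be told apart, and no measurement at hand explains this tolerance.

From the compounds shown here alone, whether an amine or a carboxylic acid on this carbon would leave the maximal response just as level remains open. Going by these compounds, this read-out gives only the largest response, so how much of each compound is needed to reach it also stays unknown.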